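The source may hold more compounds than are shown below. What is called first, only, known or untested is meant among the compounds shown, and "the series" means these compounds.

Measured so far:
compound 1 `CCCCN1CCc2nc(C#Cc3ccccc3)sc2C1` — 110 nM
compound 2 `O=C(C1CCCC1)N1CCc2nc(C#Cc3ccccc3)sc2C1` — 19 nM
compound 3 `O=C(N1CCC(F)CC1)N1CCc2nc(C#Cc3ccccc3)sc2C1` — 74 nM

In an assay on HEK293 cells for positive allosteric modulation of metabotropic glutamate receptor 5 (Homo sapiens), read by FLIPR, with a stated time of 1 h (on this read-out higher numbers stand for an effect only at larger amounts of compound and lower numbers for an effect already at smaller amounts), compound 3 stands second highest of the three numbers; compound 1 lies within the scatter of it, while compound 2 gives a clearly lower number, shown by a 3.9-fold higher number from compound 2 to compound 3 (0.59 log units; beyond the scatter). Compound 4 `O=C(N1CCCC1)N1CCc2nc(C#Cc3ccccc3)sc2C1` differs from compound 3 by pyrrolidin-1-yl in place of 4-fluoropiperidin-1-yl on a carbonyl carbon. For the measured compounds named here, only the step of a 3.9-fold higher number from compound 2 to compound 3 (0.59 log units; beyond the scatter) touches the group on the carbonyl carbon; the step of a 5.8-fold lower number from compound 1 to compound 2 (0.76 log units; beyond the scatter) concerns the amine nitrogen instead. Both steps were modest, so for compound 4 a change of similar or smaller size is expected, most likely a somewhat lower number, as a 1.5-fold lower number from compound 3 to compound 4 (0.17 log units; within the scatter). Compound 4 is estimated at 50 nM, with a range from 20 nM to 130 nM.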

Compound 4, half-maximal effective concentration: 9.8 nM
Estimate against measurement, compound 4: 5.1-fold (0.71 log units) above; measured number below the stated range.
By their numbers in this assay, from the lowest: compounds 4 and 2 (each within the scatter of the next); then compounds 3 and 1 (each within the scatter of the next).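

The carbonyl carbon accepts a group attached through a ring nitrogen: pyrrolidin-1-yl in place of 4-fluoropiperidin-1-yl gives a 7.6-fold lower number from compound 3 to compound 4 (0.88 log units; beyond the scatter), so the loss seen with compound 3 is not general to such groups. Pyrrolidin-1-yl and cyclopentyl cannot be told apart, with a 1.9-fold lower number from compound 2 to compound 4 (0.29 log units; within the scatter), while the change from butyl gives an 11-fold lower number from compound 1 to compound 4 (1.05 log units; beyond the scatter), the largest step so far. No measured evidence bears on this result.

Still open, going by these compounds, is whether ring size or the fluorine separates compound 3 from compound 4, which unsubstituted piperidin-1-yl on the carbonyl carbon would settle. Also open, on these data alone, is how an open-chain dimethylamino group would fare there.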